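Working notes on a weak-inhibitor series and a planned analogue

The compounds below may be only part of what the source reports. "The series", "measured", "known", "first", "only" and "open" are said of these compounds alone.

Measured so far:
compound 1 `O=c1cc(Cn2cc(CCCCl)nn2)c2ccc(O)cc2o1`: 30100 nM
compound 2 `CCCC1CCC(c2ccc(-c3cn(Cc4cc(=O)oc5cc(O)ccc45)nn3)cc2)CC1`: 41000 nM

In a functional assay on A549 cells (Homo sapiens) for inhibition, read by MTT assay, with a stated time of 72 h (on this read-out higher numbers stand for weaker inhibition and lower numbers for stronger inhibition), compound 1 gives 30100 nM. For the measured compounds named here, compound 2 gives 41000 nM, a number within the usual scatter of the one for compound 1, so the two cannot be ordered. Compound 3 `O=c1cc(Cn2cc(CSC(=S)N3CCNCC3)nn2)c2ccc(O)cc2o1` is not yet measured. It differs from compound 1 by a group of 9 heavy atoms (5 carbon, 2 nitrogen, 2 sulfur; one six-membered non-aromatic ring with 2 hetero atoms) in place of a group of 3 heavy atoms (2 carbon, 1 chlorine; no ring), on a saturated chain carbon bound to an aromatic carbon. Going by the values given here, no step between measured compounds bears on this change, so nothing measured points in either direction. A modest lowering of the number, close to the edge of the scatter, is the step expected for a 2.0-fold lower number from compound 1 to compound 3 (0.30 log units; within the scatter). Compound 3 is expected to give 15000 nM, in a range from 4000 nM to 60000 nM.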

Compound 3, half-maximal inhibitory concentration: 96000 nM
The estimate for compound 3 lay 6.4-fold (0.81 log units) below the measured number, and the stated range ends below it.
By their numbers in this assay, from the lowest: compounds 1 and 2 (each within the scatter of the next); then compound 3.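

This position is not indifferent to what it carries. In this assay, a group of 9 heavy atoms with one six-membered non-aromatic ring in place of 2-chloroethyl, on a saturated chain carbon bound to an aromatic carbon, gives a 3.2-fold higher number from compound 1 to compound 3 (0.50 log units; beyond the scatter) and so moves towards weaker inhibition. Nothing available explains this step.

Open, from the compounds shown here alone, is whether the ring or the two sulfur atoms carry the step. Also open, going by these compounds, is how a primary amine or a longer alkyl chain would read at this place.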